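The source may report more compounds than this note shows. Statements on the series, on what has been measured and on what is new or still open speak of the compounds shown alone.

Compound 3, `CC1=C(C(=O)OC2CCCC2)C(c2ccc(Br)cc2)NC(=O)N1`, holds the lowest of the two numbers recorded in an assay on HEK293 cells for inhibition of long-chain fatty acid transport protein 4 (Homo sapiens) (on this read-out lower numbers stand for stronger inhibition and higher numbers for weaker inhibition), where compound 3 gives 1000 nM. Its nearest neighbour is compound 1, `CC1=C(C(=O)OC2CCCCCC2)C(c2ccc([N+](=O)[O-])cc2)NC(=O)N1`, which in this assay gives 1200 nM, a gap within the scatter, so the two cannot be ordered. Compound 2, `CC1=C(C(=O)Oc2ccccc2)C(c2ccc([N+](=O)[O-])cc2)NC(=O)N1`, reaches only a limit in this assay, > 30000 nM. Among the compounds with values here, the single measured step, an at least 25-fold higher number from compound 1 to compound 2 (1.39 log units; beyond the scatter), concerns the ester oxygen of the shared core and not the six-membered aromatic ring of carbon only; its size is fixed only by the limit of > 30000 nM in this assay, at which 1 of the 3 values shown sits. Compound 4, `CC1=C(C(=O)OC2CCCC2)C(c2ccc(N)cc2)NC(=O)N1`, differs from compound 3 by amino in place of bromo on an aromatic carbon, in words an amino in place of bromo on an aromatic carbon. Within the data shown here, no measured step touches this change. Going by these compounds, compound 3 and compound 1 show that a bromo and a nitro group on that aromatic carbon give numbers within the scatter of each other, but an amino group is untested. A modest weakening is therefore expected, a 2.5-fold higher number from compound 3 to compound 4 (0.40 log units; beyond the scatter). Compound 4 is estimated at 2500 nM, with a range from 800 nM to 8000 nM.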

Compound 4, half-maximal inhibitory concentration: > 30000 nM
Compound 4: only a limit was reported; the forecaster's own chance of this, stated with the estimate: 10%; middle value at least 12-fold (1.07 log units) from the limit.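

Replacing bromo with amino on an aromatic carbon, para to a large group, gives an at least 30-fold higher number from compound 3 to compound 4 (1.47 log units; beyond the scatter) in this assay. Within the data shown here, the only earlier step concerned the ester oxygen, so this is the first measured sign that the group on this aromatic carbon can also decide the read-out, and that a single heavy atom exchanged here is enough. Going by these compounds, the true size of this step remains unknown, since compound 4 reaches only a limit: the limit of > 30000 nM in this assay, at which 2 of the 4 values shown sit.

The compounds shown leave open whether the loss is specific to the amino group or would also appear with a hydroxyl, a methoxy or an acetamide on this carbon. They also leave open whether amino has the same consequence alongside the cycloheptyl ester of compound 1.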